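Methoxy to hydroxy: what to expect for compound 4

The compounds below may be only part of what the source reports. "The series", "measured", "known", "first", "only" and "open" are said of these compounds alone.

- compound 1 (`COc1ccc(/C=C/c2cc(C)no2)cc1OC`) gives 79900 nM here
- compound 2 (`Cc1cc(/C=C/c2ccc(O)c(O)c2)on1`) gives 8900 nM here
- compound 3 (`COc1ccc(/C=C/c2cc(C)no2)cc1`) gives 69300 nM here

These values come from a functional assay on MDA-MB-231 cells (Homo sapiens) for cytotoxicity, read by MTT assay, with a stated time of 72 h (on this read-out higher numbers stand for weaker inhibition and lower numbers for stronger inhibition), and compound 3 sits level with compound 1 and clearly higher than compound 2, second highest of the three. Compound 4 (`Cc1cc(/C=C/c2ccc(O)cc2)on1`) differs from compound 3 in one place: hydrogen in place of methyl on an oxygen on an aromatic ring (hydrogen in place of methyl on an oxygen on an aromatic ring, so methoxy to hydroxy).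

For the measured compounds named here, the one measured step, a 1.2-fold lower number from compound 1 to compound 3 (0.06 log units; within the scatter), removes a methoxy instead of converting it, so it bears on this change only loosely. Closer evidence comes from a comparison of two values: compound 1 gives 79900 nM with methoxy, while compound 2 gives 8900 nM with hydroxy in more places than compound 4 would have. Only part of that gap should carry over. Going by the values given here, the expected change is a 2.3-fold lower number from compound 3 to compound 4 (0.36 log units; beyond the scatter), a moderate estimated move toward a lower number in this assay for the single swap. For compound 4 the estimated value is 30000 nM (expected range 12000 nM to 70000 nM).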

Compound 4, half-maximal inhibitory concentration: 55500 nM
The estimate for compound 4 lay 1.9-fold (0.27 log units) below the measured number; the measured number falls inside the stated range.
By their numbers in this assay, from the lowest: compound 2; then compounds 4, 3 and 1 (each within the scatter of the next).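

In this assay, turning the methoxy of compound 3 into the hydroxy of compound 4 barely registers: a 1.2-fold lower number from compound 3 to compound 4 (0.10 log units; within the scatter) is all it gives, so a single swap on this oxygen does not by itself move the number. The hydroxy that compound 2 carries in addition does matter, with a 6.2-fold higher number from compound 2 to compound 4 (0.79 log units; beyond the scatter) on going to hydrogen in its place, so the clear gap belongs to that extra hydroxy and not to the methoxy-to-hydroxy change studied here. No other measurement is available to explain either step.

On these data alone, whether an amine in place of the hydroxy of compound 4 would stay level with compound 4 or approach compound 2 remains open. So does the effect of a longer chain on that oxygen, such as ethoxy.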